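Swapping a Triazolylmethyl Arm for Phenoxy on One Core

This account rests on a few compounds, and the source may have more. Where it says the series, first, only, none or still open, it means among the compounds named here.

Compound 1 `CN(C)[C@H]1C[C@H](c2c[nH]c3ccc(C(N)=O)cc32)C1`: 14.8 nM
Compound 2 `CN(C)[C@H]1C[C@H](c2c[nH]c3ccc(C(=O)NCc4ccccc4)cc32)C1`: 141 nM
Compound 3 `Cc1nc(Cc2ccc3[nH]cc([C@H]4C[C@H](N(C)C)C4)c3c2)n[nH]1`: 2040 nM

These three compounds share one core and were measured in an assay on CHO-K1 cells for binding affinity to 5-hydroxytryptamine receptor 1D (Homo sapiens); on this read-out lower numbers stand for stronger inhibition and higher numbers for weaker inhibition. Compound 3 gives the highest number of the three: compound 1 gives 14.8 nM and a 140-fold higher number from compound 1 to compound 3 (2.14 log units; beyond the scatter); compound 2 gives 141 nM, a smaller gap but still outside the scatter. Compound 4 `CN(C)[C@H]1C[C@H](c2c[nH]c3ccc(Oc4ccccc4)cc32)C1` has not been measured; it carries phenoxy in place of (5-methyl-1H-1,2,4-triazol-3-yl)methyl on an aromatic carbon. Among the measured compounds shown here, two measured steps bear on this. a 140-fold higher number from compound 1 to compound 3 (2.14 log units; beyond the scatter) shows that the triazolylmethyl arm in place of carbamoyl gave a large rise, whereas a 9.5-fold higher number from compound 1 to compound 2 (0.98 log units; beyond the scatter) shows that adding a six-membered aromatic ring of carbon only onto the carbamoyl gave a modest rise. Phenoxy likewise brings such a ring, so compound 4 is expected to fall between those two cases, giving a 4.1-fold lower number from compound 3 to compound 4 (0.61 log units; beyond the scatter). The estimate for compound 4 is 500 nM, within a range from 100 nM to 3000 nM.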

Compound 4, half-maximal inhibitory concentration: 64.6 nM
The estimate for compound 4 lay 7.7-fold (0.89 log units) above the measured number; the measured number lies below the stated range.
By their numbers in this assay, from the lowest: compound 1; then compound 4; then compound 2; then compound 3.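

At this aromatic carbon, phenoxy in place of (5-methyl-1H-1,2,4-triazol-3-yl)methyl gives a 32-fold lower number from compound 3 to compound 4 (1.50 log units; beyond the scatter) even though both groups hold 7 heavy atoms, so the atom count of the group does not set the number in this assay here. Phenoxy in place of carbamoyl still gives a 4.4-fold higher number from compound 1 to compound 4 (0.64 log units; beyond the scatter) and compound 1 keeps the lowest number of the four. Nothing available explains these differences. Still open, on these data alone, is whether the oxygen link matters, which a benzyloxy or directly attached phenyl group would test, and how an amine would compare at this place.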